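From Compound 2 to Compound 3: One Larger Group

A few compounds are considered here, and "the series" means these few. Any claim that something is new, unique, unknown or untested is made for them only; others in the source may bear on it.

Compound 1 `COc1cc(-c2cc(=O)c3ccc(O)cc3o2)cc(OC)c1OC` reads 51400 nM in a functional assay for inhibition, read by fluorescence and spectrophotometry, with a stated time of 30 h (on this read-out higher numbers stand for weaker inhibition and lower numbers for stronger inhibition), and compound 2 `COc1ccc(-c2cc(=O)c3ccc(OCCCN4CCC(CCO)CC4)cc3o2)cc1` reads 43200 nM on the same scale. These two values lie within the usual scatter of each other, so compound 2 stands level with compound 1, with no order between them. Among the compounds with values here, the two compounds differ in more than one place, and no measured pair isolates a single change.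

Compound 3 `COc1ccc(-c2cc(=O)c3ccc(OCCCCCN4CCC(CCO)CC4)cc3o2)cc1` departs from compound 2 in one place only, on a saturated chain carbon, three bonds along the chain from an oxygen on an aromatic ring. The difference is a group of 11 heavy atoms (9 carbon, 1 nitrogen, 1 oxygen; one six-membered non-aromatic ring with 1 hetero atom) in place of a group of 9 heavy atoms (7 carbon, 1 nitrogen, 1 oxygen; one six-membered non-aromatic ring with 1 hetero atom), on a saturated chain carbon, three bonds along the chain from an oxygen on an aromatic ring and the 4-(2-hydroxyethyl)piperidin-1-yl group is what leaves.

Nothing measured shows what this change does, so the expectation starts from compound 2 at 43200 nM and allows a wide margin on both sides. No step beyond the scatter is expected in this assay for this change. The estimated step is a 1.2-fold lower number from compound 2 to compound 3 (0.09 log units; within the scatter) and it would leave the two compounds level. Compound 3 is expected to read 35000 nM (12000 nM to 90000 nM).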

Compound 3, half-maximal inhibitory concentration: 49400 nM
Estimate against measurement, compound 3: 1.4-fold (0.15 log units) below, and the stated range covers the measured number.
By their numbers in this assay, from the lowest: compounds 2, 3 and 1 (each within the scatter of the next).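

In this assay, the only single-place comparison shown puts a group of 11 heavy atoms in place of the 4-(2-hydroxyethyl)piperidin-1-yl group, on a saturated chain carbon, three bonds along the chain from an oxygen on an aromatic ring, and this gives a 1.1-fold higher number from compound 2 to compound 3 (0.06 log units; within the scatter). Compound 2 and compound 3 therefore stand level, so at this position this larger group, which keeps the six-membered non-aromatic ring with 1 hetero atom, the 1 hydrogen-bond donor, the 2 hydrogen-bond acceptors and no net charge, brings no readable change in this assay. No supporting evidence bears on this result, and the reason for it remains unknown.

A single step cannot show whether a longer chain would also leave the reading level, or whether the same holds for groups that differ more from the 4-(2-hydroxyethyl)piperidin-1-yl group, such as a carboxylic acid or a primary amine. From the compounds shown here alone, it also remains open whether any change at this position can move the reading in this assay beyond the usual scatter.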